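Carbamate chain variation on the saturated core with methylsulfonyl aryl

The compounds below may be only part of what the source reports. "The series", "measured", "known", "first", "only" and "open" are said of these compounds alone.

Three compounds carry the same saturated-chain ester on a ring nitrogen. Compound 1 `CC(C)OC(=O)N1CCC(Oc2cccc3c2CCN3c2ccc(S(C)(=O)=O)cc2F)CC1` and compound 2 `CC(C)OC(=O)N1CCC(Oc2ncnc3c2CCN3c2ccc(C#N)cc2F)CC1` and compound 3 `CCCOC(=O)N1CCC(Oc2ncnc3c2CCN3c2ccc(S(C)(=O)=O)cc2F)CC1` were measured in a functional assay on CHO-K1 cells with Glucose-dependent insulinotropic receptor (Homo sapiens) as the target, read by a luciferase reporter, with a stated time of 5 h; a lower number here means a smaller maximal response, a higher number a larger maximal response. Compound 1 gives 62%, compound 2 gives 134%, and compound 3 gives 111%. Compound 3 stands second highest of the three; its nearest neighbour, compound 2, lies beyond the scatter above it, and compound 1, the furthest, lies beyond the scatter below it. For the measured compounds named here, compound 2 differs from compound 3 in two places, compound 1 in two others, so no single-change step is available from the measured numbers.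

Compound 4 `COCCOC(=O)N1CCC(Oc2ncnc3c2CCN3c2ccc(S(C)(=O)=O)cc2F)CC1` is not yet measured. It differs from compound 3 in one place: methoxy in place of methyl on a saturated chain carbon, two bonds along the chain from an oxygen next to a carbonyl group. The change sits on a saturated chain carbon, two bonds along the chain from an oxygen next to a carbonyl group, away from the fused ring system and the fluoro-aryl part, which are unchanged.

With no measured step of this kind in the series, the expectation for compound 4 is a step within the scatter, perhaps slightly downward, the estimated step being a number 7 percentage points lower from compound 3 to compound 4 (within the scatter). Compound 4 is therefore expected at about 104%, between 84% and 124%.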

Compound 4, largest response reached (reported as percent of maximum), in percent of the reference or control that the assay uses: 86%
Beside the measured number, compound 4's estimate is 18 percentage points above it; low and high end bracket the measured number.
By their numbers in this assay, from the lowest: compound 1; then compound 4; then compound 3; then compound 2.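

The series now has its first single-change step: propyl to 2-methoxyethyl on the carbamate, with the fused ring system and the fluoro-aryl part unchanged, gives in this assay a number 25 percentage points lower from compound 3 to compound 4 (beyond the scatter). For the compounds shown here, the chain end at this position therefore affects the maximal response by itself, which the earlier compounds could not show because each pair among them differs in more than one place. No accompanying measurement bears on this step, so the data offer no explanation for it.

On these data alone, this remains a single step on a single background, so it is open whether the same change would give a comparable step with the nitrile-bearing aryl of compound 2 or on the core of compound 1. Also open, as far as these compounds go, is how this assay would respond to a longer chain such as butyl, or to a chain ending in an amine or a carboxylic acid, and so whether the step reflects the oxygen in the chain or applies more widely to changes at this carbon.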